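The source may report more compounds than this note shows. Statements on the series, on what has been measured and on what is new or still open speak of the compounds shown alone.

In a functional assay on WiDr cells (Homo sapiens) for inhibition, read by sulforhodamine B assay, with a stated time of 48 h (on this read-out lower numbers stand for stronger inhibition of growth and higher numbers for weaker inhibition of growth), two compounds that share one core were measured first. Compound 1 `COC(=O)[C@@]1(C)CCC=C2[C@@H]1CC[C@@H](C)[C@]2(C)Cc1c(C)[nH]c2ccc(Cl)cc12` gives 18000 nM. Compound 2 `COC(=O)[C@@]1(C)CCC=C2[C@@H]1CC[C@@H](C)[C@]2(C)Cc1c(C)[nH]c2ccc(F)cc12` gives 17000 nM. Among the measured compounds shown here, the single change between them is fluoro in place of chloro on an aromatic carbon and it made a 1.1-fold lower number from compound 1 to compound 2 (0.02 log units; within the scatter).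

Compound 3 `COC(=O)[C@@]1(C)CC[C@@H]2C3=C1CC[C@@H](C)[C@]3(C)C[C@@H]1c3cc(Cl)ccc3N[C@H]21` is built on a different core; the difference between the two cores is not broken down here. In this assay compound 3 gives 48000 nM, the highest of the three numbers, and its gap to compound 1 and to compound 2 lies beyond the scatter in each case.

Compound 4 `COC(=O)[C@@]1(C)CC[C@@H]2C3=C1CC[C@@H](C)[C@]3(C)C[C@@H]1c3cc(F)ccc3N[C@H]21` has not yet been measured. It differs from compound 3 by fluoro in place of chloro on an aromatic carbon. For the measured compounds named here, this is the same kind of change as the one from compound 1 to compound 2, fluoro in place of chloro on an aromatic carbon, though the surroundings are not identical: here the aromatic ring is part of a fused or bridged system of five rings, whereas in the earlier pair it is part of a fused or bridged system of two rings. Because the step of a 1.1-fold lower number from compound 1 to compound 2 (0.02 log units; within the scatter) lay within the scatter, the step from compound 3 to compound 4 is expected to be small as well, estimated as a 1.1-fold lower number from compound 3 to compound 4 (0.04 log units; within the scatter). Compound 4 is therefore expected to give about 44000 nM in this assay, with a likely range from 22000 nM to 90000 nM.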

Compound 4, concentration for 50% growth inhibition: 32000 nM
The estimate for compound 4 lay 1.4-fold (0.14 log units) above the measured number, and the stated range covers the measured number.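

In this assay, fluoro in place of chloro on an aromatic carbon gave a 1.5-fold lower number from compound 3 to compound 4 (0.18 log units; within the scatter), so on this core the exchange of one halogen for the other left no readable change in growth inhibition. Set beside the earlier pair, the step shows no readable difference between the two cores: the same change on two cores in this assay, a 1.1-fold lower number (0.02 log units; within the scatter) from compound 1 to compound 2 and a 1.5-fold lower number (0.18 log units; within the scatter) from compound 3 to compound 4, 1.4-fold (0.15 log units) apart, within the scatter of two such steps. Among the compounds shown here, this shows that, for these two pairs, the exchange behaved alike on both cores, but it rests on only two small steps and does not show that the same would hold on any other core, nor what either halogen contributes, since no compound here lacks a halogen at this place.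

The compounds shown carry only chloro or fluoro on this aromatic carbon, so it remains open what a bromo, methoxy or nitrile group there would do to the number on either core, and whether any such group would give a step beyond the scatter. As far as these compounds go, it also remains open how a carboxylic acid or an amide in place of the methyl ester would read in this assay, and whether the two cores would then respond alike.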